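Purine urea series: ester and Weinreb amide side chains

The source may report more compounds than this note shows. Statements on the series, on what has been measured and on what is new or still open speak of the compounds shown alone.

Two compounds of this series have been run in a functional assay on UACC-257 cells (Homo sapiens) for antiproliferative activity; a higher number here means a weaker inhibitor of growth, a lower number a stronger inhibitor of growth. Compound 1 `CCOC(=O)C[C@H]1[C@@H](O[Si](C)(C)C(C)(C)C)[C@H](n2cnc3c(NC(=O)Nc4ccccc4)ncnc32)O[C@@H]1COC(=O)NC` gives 20.8 nM in this assay. Compound 2 `CNC(=O)NC[C@H]1O[C@@H](n2cnc3c(NC(=O)Nc4ccccc4)ncnc32)[C@H](O[Si](C)(C)C(C)(C)C)[C@@H]1CC(=O)N(C)OC` gives 22.6 nM in this assay; this is the higher of the two numbers, but compound 1 sits within the scatter of it, so the two values show no difference. Within the data shown here, no single-point step between measured compounds is available.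

Compound 3 `CCOC(=O)C[C@H]1[C@@H](O[Si](C)(C)C(C)(C)C)[C@H](n2cnc3c(NC(=O)Nc4ccccc4)ncnc32)O[C@@H]1CNC(=O)NC` is the next entry to be measured in this assay. It differs from compound 2 by ethoxy in place of methoxy(methyl)amino on a carbonyl carbon. The change stands on a carbonyl carbon whose other neighbour is a saturated chain carbon; the rest of the molecule is kept.

Compound 1 already carries the ethoxycarbonyl side chain and its value in this assay stays level with compound 2, so the step of a 1.1-fold lower number from compound 2 to compound 3 (0.03 log units; within the scatter) is expected to be none beyond the scatter. Compound 3 is estimated at 21 nM in this assay, with a range from 10 nM to 45 nM.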

Compound 3, concentration for 50% growth inhibition: 5.68 nM
Compound 3: middle estimate off by 3.7-fold (0.57 log units), on the high side; measured number outside the range, below it.
By their numbers in this assay, from the lowest: compound 3; then compounds 1 and 2 (each within the scatter of the next).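

In this assay ethoxy in place of methoxy(methyl)amino on a carbonyl carbon gives a 4.0-fold lower number from compound 2 to compound 3 (0.60 log units; beyond the scatter) and so shows that this position responds to the change when (methylcarbamoyl)amino is present. The change from (methylcarbamoyl)oxy to (methylcarbamoyl)amino on a saturated chain carbon bound to a saturated ring carbon gives a 3.7-fold lower number from compound 1 to compound 3 (0.56 log units; beyond the scatter) and makes compound 3, which carries ethoxy and (methylcarbamoyl)amino together, the strongest inhibitor of growth of the three. Compound 1 and compound 2 differ in two places, so their level values could not reveal either step.

From the compounds shown here alone, it remains open whether a longer alkoxy chain such as butoxy, a carboxylic acid or a simple amine on the same carbonyl carbon would keep the lower number. Nothing available explains either step.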